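The compounds below may be only part of what the source reports. "The series", "measured", "known", "first", "only" and "open" are said of these compounds alone.

Three compounds sharing one core were tested in a functional assay on IMR-32 cells (Homo sapiens) for antiproliferative activity, read by sulforhodamine B assay, with a stated time of 48 h; on this read-out higher numbers stand for weaker inhibition and lower numbers for stronger inhibition. There compound 1 (`COc1ccc(C[C@@H](O)/C=C/C=C/C(=O)NCc2ccc(Cl)cc2)cc1OC`) gives 15700 nM, compound 2 (`COc1ccc(C[C@@H](O)/C=C/C=C/C(=O)N2CCN(c3ccccc3)CC2)cc1OC`) gives 9430 nM and compound 3 (`COc1ccc(C[C@@H](O)/C=C/C=C/C(=O)NCc2cc(OC)c(OC)c(OC)c2)cc1OC`) gives 13400 nM. Compound 2 lies within the scatter of both compound 1 and compound 3, so these numbers do not separate it from either. Compound 4 (`COc1ccc(C[C@@H](O)/C=C/C=C/C(=O)N2CCN(c3ncccn3)CC2)cc1OC`), not yet measured, carries pyrimidin-2-yl in place of phenyl on an amine nitrogen in a ring. Within the data shown here, no measured pair shows such a change, so no shift beyond the scatter, in either direction, is expected in this assay. The expected step is a 1.2-fold higher number from compound 2 to compound 4 (0.07 log units; within the scatter). For compound 4 the estimated value is 11000 nM, with an expected range of 6000 nM to 20000 nM.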

Compound 4, half-maximal inhibitory concentration: 10800 nM
Compound 4: middle estimate off by 1.0-fold (0.01 log units), on the high side, within the range that was stated.
By their numbers in this assay, from the lowest: compounds 2, 4, 3 and 1 (each within the scatter of the next).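

In this assay the exchange of phenyl for pyrimidin-2-yl on an amine nitrogen in a ring gives the first step measured at this position (a 1.1-fold higher number from compound 2 to compound 4 (0.06 log units; within the scatter)). The change adds 2 hydrogen-bond acceptors and ring nitrogen without moving the number beyond the scatter, so these two aromatic rings are not told apart here. Nothing measured here offers an explanation for this result. Going by these compounds, it remains open whether a non-aromatic group on this nitrogen, such as an acetyl or a simple alkyl chain, would produce a step beyond the scatter.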